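Replacing the phenyl of compound 1 with acetamido

The source may hold more compounds than are shown below. What is called first, only, known or untested is meant among the compounds shown, and "the series" means these compounds.

Measured compounds in an assay for inhibition of squalene synthase (Rattus norvegicus), using microsomes; a lower number here means a stronger inhibitor, a higher number a weaker inhibitor:
- compound 1, `CC(C)NCCCOc1ccc(-c2ccccc2)cc1`, gives 170 nM
- compound 2, `C=CCc1cc(C(=O)CCC)ccc1OCCCNC(C)C`, gives 1 nM
- compound 3, `C=CCc1cc(-c2ccccc2)ccc1OCCCNC(C)C`, gives 0.004 nM

Compound 1 stands highest of the three numbers in this assay. Compound 2 gives a number far lower than compound 1, and the measured step of a 43000-fold lower number from compound 1 to compound 3 (4.63 log units; beyond the scatter) is larger still. The other measured step, a 250-fold lower number from compound 2 to compound 3 (2.40 log units; beyond the scatter), shows that a phenyl on the aromatic carbon gives a much lower number than propylcarbonyl at that position.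

Compound 4, `CC(=O)Nc1ccc(OCCCNC(C)C)cc1`, differs from compound 1 by acetamido in place of phenyl on an aromatic carbon. For the measured compounds named here, no measured step covers this exchange. Going by the values given here, the only guide is the step from compound 2 to compound 3, in which phenyl gave a far lower number than a smaller, non-aromatic group, which suggests that removing the phenyl from compound 1 would move the number upward. Compound 4 is therefore expected to give a higher number than compound 1, with an estimated step of a 12-fold higher number from compound 1 to compound 4 (1.07 log units; beyond the scatter). The estimate for compound 4 is 2000 nM, with a range from 300 nM to 20000 nM.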

Compound 4, half-maximal inhibitory concentration: > 2500 nM
Compound 4: no number, only a limit; the forecaster's own chance of this, stated with the estimate: 20%; middle value at least 1.2-fold (0.09 log units) away from the limit.
By their numbers in this assay, from the lowest: compound 3; then compound 2; then compound 1. At a limit, above all of these: compound 4.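

In this assay, compound 4 gives no number, only a limit: the limit of > 2500 nM in this assay, at which 1 of the 4 values shown sits.

Acetamido in place of phenyl on this aromatic carbon gives an at least 14-fold higher number from compound 1 to compound 4 (1.16 log units; beyond the scatter), and since this step rests on a limit, its full size stays unknown. The earlier compounds showed a loss of phenyl at this position only with allyl present, whereas this step shows the same direction without allyl, and neither pair shown goes against it.

The compounds shown do not tell whether a smaller group such as methyl, or a ring such as pyridine, could stand in for phenyl at this position. They also leave open whether allyl would lower the number of compound 4 as it does that of compound 1.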